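A Methyl Removed and Its Effect on Cytotoxicity

The source may report more compounds than this note shows. Statements on the series, on what has been measured and on what is new or still open speak of the compounds shown alone.

Compound 1 `CC(C)(CCCOc1ccc(-c2ccc(Cl)cc2)cc1)CN1CCN(c2ccncc2)C1=O` is the only one of the three measured compounds to give a number in an ADME assay on cells (Homo sapiens) for cytotoxicity; on this read-out lower numbers stand for higher toxicity in this test and higher numbers for lower toxicity in this test: compound 1 gives 20000 nM. Compound 3 `CC(C)(CCCN1CCN(c2ccncc2)C1=O)COc1ccc(-c2ccc(Cl)cc2)cc1` reaches only a limit in this assay, > 25000 nM. Compound 2 `CC(CCCN1CCN(c2ccncc2)C1=O)COc1ccc(-c2ccc(Cl)cc2)cc1` likewise reaches only a limit, > 25000 nM. The change from compound 3 to compound 2 is hydrogen in place of methyl on a saturated chain carbon bound to three saturated chain carbons and its step is a step that the two limits leave unreadable from compound 3 to compound 2. Compound 1 and compound 3 have the same atoms joined differently; how the two cores differ is not broken down here. Compound 4 `CC(CCCOc1ccc(-c2ccc(Cl)cc2)cc1)CN1CCN(c2ccncc2)C1=O` differs from compound 1 by hydrogen in place of methyl on a saturated chain carbon bound to three saturated chain carbons, the same change made in the same place. The expected step is a 1.1-fold higher number from compound 1 to compound 4 (0.04 log units; within the scatter), resting on compound 1 at 20000 nM and on (the limit of > 25000 nM in this assay, at which 2 of the 3 values shown sit). Compound 4 is estimated at 22000 nM, between 12000 nM and 30000 nM.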

Compound 4, half-maximal cytotoxic concentration: > 25000 nM
Compound 4: only a limit was reported; the forecaster's own chance of this, stated with the estimate: 45%; middle value at least 1.1-fold (0.05 log units) from the limit.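

Within the data shown here, on the core of the first compound in the step, hydrogen in place of methyl gives in this assay an at least 1.2-fold higher number from compound 1 to compound 4 (0.09 log units; that floor lies within the scatter). The matching step on the other core cannot be read, so the series gives no second size against which this one could be set, and carrying the change from one core to the other is neither confirmed nor refuted. Nothing here shows the change acting alike or differently on the two cores, as most of the values rest on a limit: the limit of > 25000 nM in this assay, at which 3 of the 4 values shown sit.

The compounds shown leave open what an ethyl group, a hydroxyl or an amine in that same place would give in this assay. They also leave open whether a longer chain would bring a number rather than a limit.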